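Replacing a methyl with hydrogen on compound 2

A few compounds are considered here, and "the series" means these few. Any claim that something is new, unique, unknown or untested is made for them only; others in the source may bear on it.

Measured in a functional assay on MDA-MB-468 cells (Homo sapiens) for antiproliferative activity; on this read-out lower numbers stand for stronger inhibition of growth and higher numbers for weaker inhibition of growth:
compound 1 `COc1ccc(-c2nc3cc(F)ccc3s2)cc1OC` gives < 0.1 nM (a limit)
compound 2 `COc1cc(-c2nc3cc(F)ccc3s2)cc(OC)c1OC` gives 2.1 nM

Going by the values given here, compound 2 holds the only true number in this assay (2.1 nM). The other value, that of compound 1, is a limit. Compound 3 `COc1cc(-c2nc3cc(F)ccc3s2)cc(O)c1OC` carries one change (hydrogen in place of methyl on an oxygen on an aromatic ring), methoxy to hydroxy. Among the compounds with values here, the one measured step bearing on it is large: an at least 21-fold higher number from compound 1 to compound 2 (1.32 log units; beyond the scatter), methoxy in place of hydrogen on an aromatic carbon. That step adds a whole group, whereas here the oxygen stays, so a smaller move is expected, probably towards a higher number. The expected change is a 1.9-fold higher number from compound 2 to compound 3 (0.28 log units; within the scatter). For compound 3 the estimated value is 4 nM (range 0.4 nM to 40 nM).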

Compound 3, concentration for 50% growth inhibition: 88 nM
For compound 3 the middle estimate is 22-fold (1.34 log units) below the measured one; measured number above the stated range.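

In this assay, the oxygen stays and only its methyl goes, yet the change to hydroxy is large: a 42-fold higher number from compound 2 to compound 3 (1.62 log units; beyond the scatter). So this position responds strongly to what the oxygen carries, not only to whether an oxygen is present, and hydroxy here also stands well apart from plain hydrogen: an at least 880-fold higher number from compound 1 to compound 3 (2.94 log units; beyond the scatter). Compound 1 stands at a limit, so that last step is only a bound: the limit of < 0.1 nM in this assay, at which 1 of the 3 values shown sits.

The compounds shown leave open how an ethoxy group, with its longer chain on this oxygen, would read. They also leave open how an amine in place of the hydroxy would read.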